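Swapping the thiophene amide for a fluorophenyl amide

The source may report more compounds than this note shows. Statements on the series, on what has been measured and on what is new or still open speak of the compounds shown alone.

Compound 1 `O=C(Nc1cccc(-c2nc3ccccc3[nH]2)c1)c1cccs1`: 15000 nM
Compound 2 `Cc1ccc2[nH]c(-c3cccc(NC(=O)c4cccs4)c3)nc2c1`: 16700 nM
Compound 3 `Cn1c(-c2cccc(NC(=O)c3cccs3)c2)nc2ccccc21`: 61300 nM

All three compounds were tested in an ADME assay on NIH3T3 cells (Mus musculus) for cytotoxicity, read by resazurin assay, with a stated time of 48 h; a lower number here means a stronger inhibitor, a higher number a weaker inhibitor. Compound 1 gives the lowest number of the three, but compound 2 sits within the scatter of it, as the step of a 1.1-fold higher number from compound 1 to compound 2 (0.05 log units; within the scatter) shows, so no order between them can be claimed. Compound 3 is the only one set apart: the step of a 4.1-fold higher number from compound 1 to compound 3 (0.61 log units; beyond the scatter) is modest but beyond the scatter.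

Compound 4 `O=C(Nc1cccc(-c2nc3ccccc3[nH]2)c1)c1ccc(F)cc1` differs from compound 1 in one place: 4-fluorophenyl in place of thiophen-2-yl on a carbonyl carbon. Neither measured step touches this part of the molecule. Both steps altered the shared core, one by a methyl on an aromatic carbon and one by a methyl on an aromatic nitrogen, while the amide side was left alone. Nothing measured here therefore speaks directly to the exchange of one aromatic amide group for another, and the best guide is compound 1 itself at 15000 nM.

Within the data shown here, with no step to lean on, compound 4 is expected to land close to compound 1, the estimated step of a 1.2-fold higher number from compound 1 to compound 4 (0.08 log units; within the scatter) lying within the usual scatter. Compound 4 is accordingly estimated at 18000 nM, with a range from 7000 nM to 45000 nM.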

Compound 4, half-maximal inhibitory concentration: 15400 nM
Beside the measured number, compound 4's estimate is 1.2-fold (0.07 log units) above it; measured number inside the range.
By their numbers in this assay, from the lowest: compounds 1, 4 and 2 (each within the scatter of the next); then compound 3.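

In this assay, putting 4-fluorophenyl in place of thiophen-2-yl on a carbonyl carbon gives a 1.0-fold higher number from compound 1 to compound 4 (0.01 log units; within the scatter), so exchanging a five-membered aromatic ring with one hetero atom for a six-membered aromatic ring of carbon only makes no readable difference. Among these compounds, the earlier steps touched only the shared core, so this is the first reading from the amide side of the molecule, and it shows that one aromatic group can stand in for the other there. No measurement at hand explains why the two groups read alike.

From the compounds shown here alone, whether an open carbon chain, or an aromatic ring carrying an amine or a carboxylic acid, would behave the same way on this carbonyl carbon remains open. Among the compounds shown here, also open is whether 4-fluorophenyl would match thiophen-2-yl on the core of compound 3, the only compound set apart so far.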